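Removing the methoxy group from a diarylheptanoid diol

The source may report more compounds than this note shows. Statements on the series, on what has been measured and on what is new or still open speak of the compounds shown alone.

Measured so far:
compound 1, `COc1cc(CC[C@@H](O)C[C@@H](O)CCc2ccc(O)cc2)ccc1O`, 2810 nM
compound 2, `COc1cc(CC[C@@H](O)C[C@@H](O)CCc2ccc(O)cc2)cc(O)c1O`, 2410 nM

Compound 1 stands highest of the two numbers measured in a functional assay on RAW264.7 cells (Mus musculus) for inhibition, read by spectrophotometry and Griess assay, with a stated time of 24 h (on this read-out higher numbers stand for weaker inhibition and lower numbers for stronger inhibition), with compound 2 nearest at a 1.2-fold lower number from compound 1 to compound 2 (0.07 log units; within the scatter). The unmeasured compound 3, `Oc1ccc(CC[C@@H](O)C[C@@H](O)CCc2ccc(O)cc2)cc1`, differs from compound 1 by hydrogen in place of methoxy on an aromatic carbon. Among the compounds with values here, the only measured step, from compound 1 to compound 2, concerns a hydroxy group entering elsewhere on the same ring and lies within the scatter; no measured pair tells what removal of the methoxy group does. Within the data shown here, with that single small step as the only guide, no change beyond the scatter is expected for compound 3 in this assay, so compound 3 is estimated at 3000 nM, with a range from 1400 nM to 6500 nM. The step from compound 1 to compound 3 is expected to be a 1.1-fold higher number from compound 1 to compound 3 (0.03 log units; within the scatter).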

Compound 3, half-maximal inhibitory concentration: > 100000 nM
Compound 3: only a limit was reported; the forecaster's own chance of this, stated with the estimate: 5%; at least 33-fold (1.52 log units) between middle value and limit.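

In this assay, hydrogen in place of methoxy, ortho to a hydroxy group, gives an at least 35-fold higher number from compound 1 to compound 3 (1.55 log units; beyond the scatter). Compound 3 carries a limit of the assay and not a number: the limit of > 100000 nM in this assay, at which 1 of the 3 values shown sits. Earlier, a hydroxy group entering the same ring gave a 1.2-fold lower number from compound 1 to compound 2 (0.07 log units; within the scatter), whereas this change is the first shown to move the number beyond the scatter, so the methoxy position matters far more in this series than that small step suggested.

The compounds shown leave open whether a hydroxy group, an ethoxy group or a fluorine atom in this place would keep the number close to that of compound 1. They also leave open whether removing the methoxy group from compound 2 would produce a step of similar size, and they give no reason for the step.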